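A Methyl Group Added to a Compound at the Limit

A few compounds are considered here, and "the series" means these few. Any claim that something is new, unique, unknown or untested is made for them only; others in the source may bear on it.

In a functional assay on MCF7 cells (Homo sapiens) for inhibition, read by CCK-8 assay, with a stated time of 48 h (on this read-out lower numbers stand for stronger inhibition of growth and higher numbers for weaker inhibition of growth), compound 1 (`Cc1ccccc1Nc1nc(Nc2cccnc2)ncc1Cl`) gives 56500 nM. Compound 2 (`Cc1ccccc1Nc1nc(NC2CC2)ncc1Cl`) returns only a limit, > 100000 nM. Compound 3 (`Cc1ccccc1Nc1nc(Nc2ccccc2)ncc1Cl`) also returns only a limit, > 100000 nM, so it stands at the limit of > 100000 nM in this assay, at which 2 of the 3 values shown sit. Compound 4 (`Cc1ccc(Nc2ncc(Cl)c(Nc3ccccc3C)n2)cc1`) carries methyl in place of hydrogen on an aromatic carbon, para to a large group: methyl in place of hydrogen on an aromatic carbon. Among the measured compounds shown here, no measured step makes this change. The nearest steps replace the group on the nitrogen: an at least 1.7-fold higher number from compound 1 to compound 2 (0.24 log units; that floor lies within the scatter), and an at least 1.7-fold higher number from compound 1 to compound 3 (0.24 log units; that floor lies within the scatter). Both floors lie within the scatter, so they suggest no sizeable shift. The expected result is a number no higher from compound 3 to compound 4 (the limit leaves the size open), with no estimated change beyond the scatter. For compound 4 the estimated value is 100000 nM, with an expected range of 45000 nM to 200000 nM.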

Compound 4, concentration for 50% growth inhibition: > 100000 nM
Compound 4: a limit, no number (the forecaster's own chance of this, stated with the estimate: 65%); the middle value lies on the limit itself.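

Methyl at this position, the change from phenyl to 4-methylphenyl, does not bring the compound back to a measurable number in this assay, and compound 4 adds to the compounds held at the limit: the limit of > 100000 nM in this assay, at which 3 of the 4 values shown sit. Among the compounds shown here, the one readable new step is an at least 1.7-fold higher number from compound 1 to compound 4 (0.24 log units; that floor lies within the scatter). The other two new steps, both between limits, cannot be read.

For the compounds shown here, compound 1, with pyridin-3-yl, remains the only compound with a number. As far as these compounds go, whether an amine or a carboxylic acid at this position, in place of methyl, would give a number remains open.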